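Swapping the Pyridine Ring on a Sulfonamide Chemokine Antagonist

The compounds below may be only part of what the source reports. "The series", "measured", "known", "first", "only" and "open" are said of these compounds alone.

Compound 3 `CC(C)(C)c1ccc(S(=O)(=O)Nc2ccc(Cl)cc2-c2nccc(CO)c2O)cc1` has the lowest number of the three measured compounds in a functional assay on isolated protein for antagonist activity at C-C chemokine receptor type 9 (Homo sapiens), read by calcium flux, with a stated time of 10 min (on this read-out lower numbers stand for stronger inhibition and higher numbers for weaker inhibition), giving 8.7 nM. Compound 1 `COc1ccnc(-c2cc(Cl)ccc2NS(=O)(=O)c2ccc(C(C)(C)C)cc2)c1` gives 2500 nM in this assay, and compound 2 `CC(C)(C)c1ccc(S(=O)(=O)Nc2ccc(Cl)cc2-c2ncccc2CN)cc1` gives 3160 nM. The shared core is the same throughout; only the ring attached to it changes. That change matters greatly here: a 290-fold lower number from compound 1 to compound 3 (2.46 log units; beyond the scatter) and a 360-fold lower number from compound 2 to compound 3 (2.56 log units; beyond the scatter), whereas a 1.3-fold higher number from compound 1 to compound 2 (0.10 log units; within the scatter).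

Compound 4 `CC(C)(C)c1ccc(S(=O)(=O)Nc2ccc(Cl)cc2-c2ncncc2N)cc1` carries a further variation at the same position: a group of 7 heavy atoms (4 carbon, 3 nitrogen; one six-membered aromatic ring with 2 hetero atoms) in place of a group of 9 heavy atoms (6 carbon, 1 nitrogen, 2 oxygen; one six-membered aromatic ring with 1 hetero atom), on an aromatic carbon. The group that leaves is the one whose entry brought the large gains seen in the steps from compound 1 and compound 2 to compound 3. Among the compounds with values here, the group that enters resembles those in compound 1 and compound 2 in lacking both oxygens, though it is not identical to either, so no measured step covers it exactly.

Given that loss, a large rise in number is expected, a 170-fold higher number from compound 3 to compound 4 (2.24 log units; beyond the scatter), back toward the range of compound 1 and compound 2. Compound 4 is therefore estimated at 1500 nM in this assay, with a likely range from 250 nM to 8000 nM.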

Compound 4, half-maximal inhibitory concentration: 3.2 nM
Estimate against measurement, compound 4: 470-fold (2.67 log units) above, outside the stated range (below it).
By their numbers in this assay, from the lowest: compound 4; then compound 3; then compounds 1 and 2 (each within the scatter of the next).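

In this assay, the change gives a 2.7-fold lower number from compound 3 to compound 4 (0.43 log units; beyond the scatter), so a very low number at this position on the shared core does not depend on the 2 oxygens of the group in compound 3. The group in compound 4 has no oxygen, and neither does the group in compound 2, yet the step between them is a 990-fold lower number from compound 2 to compound 4 (2.99 log units; beyond the scatter), and a similar gap appears in a 780-fold lower number from compound 1 to compound 4 (2.89 log units; beyond the scatter), so the absence of oxygen does not by itself bring a high number, and small differences in this group can separate the strongest compounds here from the weakest. Nothing given here explains why these groups differ so sharply.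

The compounds shown leave open which part of the change matters, since the ring with 2 hetero atoms and the loss of both oxygens arrive together in compound 4. They also leave open how the number would move if a carboxylic acid or a methyl group took the place of the amine on that ring.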